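Replacing 2,6-dichlorobenzyl with 3-methoxyphenyl

The source may hold more compounds than are shown below. What is called first, only, known or untested is meant among the compounds shown, and "the series" means these compounds.

Among the compounds with values here, in a functional assay on Huh-7 cells (Homo sapiens) for cytotoxicity, read by cell counting, with a stated time of 48 h (on this read-out lower numbers stand for stronger inhibition and higher numbers for weaker inhibition), compound 2 (`Clc1cccc(Nc2ncc3cccc(OCc4cn(Cc5c(Cl)cccc5Cl)nn4)c3n2)c1`) gives 7000 nM, the lower of the two numbers measured so far. The other measured compound, compound 1 (`Cc1ccc(-n2cc(COc3cccc4cnc(Nc5cccc(Cl)c5)nc34)nn2)c([N+](=O)[O-])c1`), gives 25000 nM. The next compound is compound 3 (`COc1cccc(-n2cc(COc3cccc4cnc(Nc5cccc(Cl)c5)nc34)nn2)c1`), which carries 3-methoxyphenyl in place of 2,6-dichlorobenzyl on an aromatic nitrogen of a five-membered aromatic ring with 3 nitrogen: 3-methoxyphenyl in place of 2,6-dichlorobenzyl on an aromatic nitrogen.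

Within the data shown here, only one measured step bears on this change. It involves the same place on the molecule: a 3.6-fold lower number from compound 1 to compound 2 (0.55 log units; beyond the scatter), a modest change that lies beyond the scatter, with 2,6-dichlorobenzyl in place of 4-methyl-2-nitrophenyl. Compound 3 resembles compound 1 in having a substituted phenyl rather than a benzyl group at that nitrogen, although the substituents differ. Among the measured compounds shown here, one step is thin evidence, and no measurement yet covers 3-methoxyphenyl itself. For the measured compounds named here, compound 1, the only phenyl example, gives 25000 nM, so a partial move back toward that number seems reasonable. The expected change in this assay is a 2.1-fold higher number from compound 2 to compound 3 (0.33 log units; beyond the scatter), towards weaker inhibition. For compound 3 the estimated value is 15000 nM, with an expected range of 6000 nM to 40000 nM.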

Compound 3, half-maximal inhibitory concentration: 23000 nM
Compound 3: the middle estimate sits 1.5-fold (0.19 log units) below what was measured; the range from low to high includes it.
By their numbers in this assay, from the lowest: compound 2; then compounds 3 and 1 (each within the scatter of the next).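

In this assay, replacing 2,6-dichlorobenzyl with 3-methoxyphenyl gives a 3.3-fold higher number from compound 2 to compound 3 (0.52 log units; beyond the scatter), so a second step at this aromatic nitrogen now lies beyond the scatter, and it is again a modest one. The two substituted phenyl groups behave differently from this: the step is a 1.1-fold lower number from compound 1 to compound 3 (0.04 log units; within the scatter), so 3-methoxyphenyl and 4-methyl-2-nitrophenyl cannot be told apart on this read-out, even though their substituents differ, and among these three compounds only compound 2, with its benzyl group, stands apart. No measurement at hand explains why this group differs from the two phenyl groups.

Within the data shown here, whether the lower number of compound 2 goes with the benzyl frame or with its two chlorine atoms stays open, since that compound is the only benzyl example here. Also open, from the compounds shown here alone, is what a plain unsubstituted benzyl, or a longer chain ending in an amine or a carboxylic acid, would do on this same aromatic nitrogen of the five-membered ring.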